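The source may report more compounds than this note shows. Statements on the series, on what has been measured and on what is new or still open speak of the compounds shown alone.

Compound 1 `Cc1cc(/C=C2\SC(=S)N(c3ccccc3)C2=O)c(C)n1-c1ccc(O)c(C(=O)O)c1` in an ADME assay on MT2 cells (Homo sapiens) for cytotoxicity, read by XTT assay, with a stated time of 4 days; a higher number here means that more compound is tolerated, a lower number that less compound is tolerated: > 100000 nM
Compound 2 `COC(=O)c1cccc(CN2C(=O)/C(=C/c3cc(C)n(-c4ccc(O)c(C(=O)O)c4)c3C)SC2=S)c1` in this assay: 38500 nM

The figure for compound 1 is a limit of the assay, not a number, as the limit of > 100000 nM in this assay, at which 1 of the 2 values shown sits, records. Compound 2 therefore holds the only real number in this assay shown here. Compound 3 `Cc1cc(/C=C2\SC(=S)N(Cc3ccccc3C(F)(F)F)C2=O)c(C)n1-c1ccc(O)c(C(=O)O)c1` differs from compound 2 by 2-(trifluoromethyl)phenyl in place of 3-(methoxycarbonyl)phenyl on a saturated chain carbon bound to an amide-type nitrogen in a ring. Within the data shown here, the only measured step, an at least 2.5-fold lower number from compound 1 to compound 2 (0.41 log units; beyond the scatter), changed a different part of the group on that nitrogen and gives no direct guide to this exchange. With nothing pointing either way, compound 3 is expected to show no step beyond the scatter, estimated at 30000 nM, between 10000 nM and 100000 nM, meaning a step of a 1.3-fold lower number from compound 2 to compound 3 (0.11 log units; within the scatter).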

Compound 3, half-maximal cytotoxic concentration: 28800 nM
The estimate for compound 3 lay 1.0-fold (0.02 log units) above the measured number, within the range that was stated.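

In this assay, exchanging the aromatic ring on this saturated chain carbon gives a 1.3-fold lower number from compound 2 to compound 3 (0.13 log units; within the scatter), so the two groups cannot be told apart here, although only the leaving group carries hydrogen-bond acceptors. The 2-(trifluoromethyl)benzyl group in place of phenyl gives an at least 3.4-fold lower number from compound 1 to compound 3 (0.54 log units; beyond the scatter), in line with the earlier step for 3-(methoxycarbonyl)benzyl. The figure for compound 1 is a limit, not a number: the limit of > 100000 nM in this assay, at which 1 of the 3 values shown sits.

As far as these compounds go, it remains open whether an amine or a carboxylic acid on this ring, or a longer chain to the nitrogen, would shift the number beyond the scatter.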